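Changing the Urea Aryl Group: Compound 1 to Compound 3

This account rests on a few compounds, and the source may have more. Where it says the series, first, only, none or still open, it means among the compounds named here.

Measured so far:
Compound 1 `Cc1cc(Cl)ccc1NC(=O)Nc1nc(Sc2c[nH]c3ccccc23)cc(N2CCN(Cc3ccccc3)CC2)n1` gives > 50000 nM in a functional assay on A549 cells (Homo sapiens) for inhibition, with a stated time of 72 h (on this read-out lower numbers stand for stronger inhibition and higher numbers for weaker inhibition), which is a limit of the assay and not a number.
Compound 2 `O=C(Nc1ccc(Cl)cc1)Nc1nc(Sc2c[nH]c3ccccc23)cc(N2CCCC2)n1` gives 6410 nM in this assay.

Compound 1 thus stands at the limit of > 50000 nM in this assay, at which 1 of the 2 values shown sits; its inhibition is known only as too weak for the assay to resolve. Going by the values given here, compound 2 carries a measured number, but no single-point step connects it to compound 1, so it shows only where it itself lies.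

Compound 3 `Cc1ccc(C)c(NC(=O)Nc2nc(Sc3c[nH]c4ccccc34)cc(N3CCN(Cc4ccccc4)CC3)n2)c1` differs from compound 1 by 2,5-dimethylphenyl in place of 4-chloro-2-methylphenyl on an amide-type nitrogen. No measured step of this kind exists among the compounds shown. With compound 1 resting at a limit, the step is expected to be a number no higher from compound 1 to compound 3 (the limit leaves the size open), that is, no change beyond the scatter in either direction. Compound 3 is therefore estimated at 50000 nM, with a range from 12000 nM to 200000 nM, and a limit rather than a number is judged the more likely outcome.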

Compound 3, half-maximal inhibitory concentration: > 50000 nM
Compound 3: a limit, no number (the forecaster's own chance of this, stated with the estimate: 55%); the middle value lies on the limit itself.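

No step can be read from compound 1 to compound 3, because in this assay both stand at a limit and not at a number: the limit of > 50000 nM in this assay, at which 2 of the 3 values shown sit.

The compounds shown leave open whether 2,5-dimethylphenyl in place of 4-chloro-2-methylphenyl on an amide-type nitrogen changes inhibition at all.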